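The compounds below may be only part of what the source reports. "The series", "measured", "known", "first", "only" and "open" are said of these compounds alone.

Three compounds of the series have numbers in a functional assay on KG-1 cells (Homo sapiens) for antiproliferative activity; on this read-out higher numbers stand for an effect only at larger amounts of compound and lower numbers for an effect already at smaller amounts. Compound 1 `NC(=O)c1cc(Cl)c2c(Cl)c(C#CCCO)n([C@H]3CCCNC3)c2n1` gives 56 nM in this assay. Compound 2 `NC(=O)c1cc(Cl)c2c(Cl)c(C#CC3CCCO3)n([C@H]3CCCNC3)c2n1` has several entries in this assay, 223 nM; 91 nM (2 entries), so no single number stands for it; the spread of these entries, (the several entries of compound 2 in this assay, 223 nM; 91 nM (2 entries)), shows how far repeated runs of this assay can lie apart. Within the data shown here, compound 3 `COCCC#Cc1c(Cl)c2c(Cl)cc(C(N)=O)nc2n1[C@H]1CCCNC1` gives 39 nM, the lowest of the two single numbers, with compound 1 nearest to it; the only one-point step measured, a 1.4-fold lower number from compound 1 to compound 3 (0.16 log units; within the scatter), lies within the scatter. Compound 4 `COCC(C)(C)C#Cc1c(Cl)c2c(Cl)cc(C(N)=O)nc2n1[C@H]1CCCNC1` is not yet measured in this assay. It differs from compound 3 by 1-(methoxymethyl)-1-methylethyl in place of 2-methoxyethyl on a triple-bonded carbon. Among the measured compounds shown here, no measured step touches the carbon on the triple-bonded carbon; the one step available concerns the oxygen on the saturated carbon and was within the scatter. A step beyond the scatter is therefore not expected in either direction, and for compound 4 the number in this assay is estimated at 65 nM, between 25 nM and 200 nM, which means a step of a 1.7-fold higher number from compound 3 to compound 4 (0.22 log units; within the scatter) that is expected to stay within the scatter.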

Compound 4, half-maximal effective concentration: 219 nM
For compound 4 the middle estimate is 3.4-fold (0.53 log units) below the measured one, outside the stated range (above it).
By their numbers in this assay, from the lowest: compounds 3 and 1 (each within the scatter of the next); then compound 4.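

Among these compounds, on the triple-bonded carbon, 1-(methoxymethyl)-1-methylethyl in place of 2-methoxyethyl gives a 5.6-fold higher number from compound 3 to compound 4 (0.75 log units; beyond the scatter) in this assay, the first step to lie beyond the scatter, so this position responds to a change in the chain where the methyl on oxygen did not. The same group in place of 2-hydroxyethyl gives a 3.9-fold higher number from compound 1 to compound 4 (0.59 log units; beyond the scatter), which is also beyond the scatter, so the higher number for compound 4 holds against both unbranched chains. Compound 4 rests on a single entry, and repeated runs can lie apart: the several entries of compound 2 in this assay, 223 nM; 91 nM (2 entries)

The compounds shown do not tell whether a single methyl on the carbon attached to the triple-bonded carbon would already give this step. Going by these compounds, how an amine or a carboxylic acid at the end of the chain would read also stays open.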